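Swapping a diaminocyanothiophene for a fused ring

This account rests on a few compounds, and the source may have more. Where it says the series, first, only, none or still open, it means among the compounds named here.

Measured compounds in a functional assay on MCF7 cells (Homo sapiens) for cytotoxicity, read by sulforhodamine B assay, with a stated time of 48 h; a lower number here means a stronger inhibitor, a higher number a weaker inhibitor:
Compound 1, `C/C(=N\NC(=O)CC#N)c1ccc(S(=O)(=O)N2CCCCC2)cc1`: 44200 nM
Compound 2, `C/C(=N\NC(=O)c1sc(N)c(C#N)c1N)c1ccc(S(=O)(=O)N2CCCCC2)cc1`: 49300 nM
Compound 3, `CCOC(=O)c1c(N)sc(C(=O)N/N=C(\C)c2ccc(S(=O)(=O)N3CCCCC3)cc2)c1N`: "not active" (no number reported), reported only as inactive, with no number

Compound 2 holds the higher of the two numbers, but its nearest neighbour is compound 1 and the difference between them, a 1.1-fold higher number from compound 1 to compound 2 (0.05 log units; within the scatter), lies within the usual scatter, so the two cannot be ranked. Compound 3, with an ethyl ester on the thiophene in place of the nitrile, gave no number at all.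

Compound 4, `C/C(=N\NC(=O)c1sc2c(c1N)CCC2)c1ccc(S(=O)(=O)N2CCCCC2)cc1`, is the untested compound. Its change from compound 2 is a group of 9 heavy atoms (7 carbon, 1 nitrogen, 1 sulfur; one five-membered non-aromatic ring of carbon only, one five-membered aromatic ring with 1 hetero atom) in place of a group of 9 heavy atoms (5 carbon, 3 nitrogen, 1 sulfur; one five-membered aromatic ring with 1 hetero atom), on a carbonyl carbon; the group that enters combines one five-membered aromatic ring holding one hetero atom with one five-membered non-aromatic ring of carbon only.

Among the measured compounds shown here, the only measured step that touches this position, the exchange of cyanomethyl for 3,5-diamino-4-cyanothiophen-2-yl, was a 1.1-fold higher number from compound 1 to compound 2 (0.05 log units; within the scatter), a change too small to matter. Compound 3 shows that a further change at the same place can lead to no measurable activity. With one flat step and one inactive case, no step beyond the scatter is expected in this assay, though the chance of an inactive result is real. For compound 4 the estimate is 50000 nM, with a range of 20000 nM to 150000 nM. This corresponds to an expected step of a 1.0-fold higher number from compound 2 to compound 4 (0.01 log units; within the scatter).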

Compound 4, half-maximal inhibitory concentration: 75300 nM
Compound 4: middle estimate off by 1.5-fold (0.18 log units), on the low side, within the range that was stated.
By their numbers in this assay, from the lowest: compounds 1, 2 and 4 (each within the scatter of the next).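

In this assay, among the compounds shown here, putting the fused two-ring group on the carbonyl carbon in place of 3,5-diamino-4-cyanothiophen-2-yl gives a 1.5-fold higher number from compound 2 to compound 4 (0.18 log units; within the scatter), so this larger change of atoms at the position still produces no step that can be told from noise. The entering group has no triple bond and fewer hydrogen-bond donors and acceptors, yet compound 4 still gives a measurable number, so neither the nitrile nor the full set of amino groups is needed for a reading in this assay. Set against the open-chain cyanomethyl group, the same group gives a 1.7-fold higher number from compound 1 to compound 4 (0.23 log units; within the scatter), so adding a second ring also leaves the number within the scatter, and no measurement at hand explains this flat behaviour.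

As far as these compounds go, whether any group on this carbonyl carbon can move the number beyond the scatter remains open, for example a plain phenyl ring or a dimethylamino group. It is also unclear whether the inactive result of compound 3 belongs to the ethyl ester itself, a question that a carboxylic acid or a methyl ester in its place would help to answer.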